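The compounds below may be only part of what the source reports. "The series", "measured", "known", "first", "only" and "open" are said of these compounds alone.

In an in vitro ADME assay on microsomes from liver (Mus musculus) for pharmacokinetics, read by LC-MS, with a stated time of 10 min, tested at 1 uM (on this read-out higher numbers stand for fast clearance and lower numbers for slow clearance), compound 1 `CC(C)N1C[C@H](C(=O)Nc2ccc(Cl)cc2)[C@@H](c2ccc(/C=C/C(=O)Nc3ccccc3N)cc2)C1` gives 38 mL/min/kg and compound 2 `CCNC(=O)N1C[C@H](C(=O)Nc2ccc(Cl)cc2)[C@@H](c2ccc(/C=C/C(=O)Nc3ccccc3N)cc2)C1` gives 25 mL/min/kg so the two stand within the usual scatter of each other. Compound 3 `CCN(CC)C(=O)N1C[C@H](C(=O)Nc2ccc(Cl)cc2)[C@@H](c2ccc(/C=C/C(=O)Nc3ccccc3N)cc2)C1` differs from compound 2 by ethyl in place of hydrogen on an amide-type nitrogen in the form of ethyl in place of hydrogen on an amide-type nitrogen. Within the data shown here, the one measured step, a 1.5-fold lower number from compound 1 to compound 2 (0.18 log units; within the scatter) with ethylcarbamoyl in place of isopropyl on an amine nitrogen in a ring, is a different change and lay within the scatter. It is only a loose guide, and this assay is expected to show no step beyond the scatter. The estimated step is a 1.2-fold higher number from compound 2 to compound 3 (0.08 log units; within the scatter) and it is expected to stay within the scatter. Compound 3 is estimated at 30 mL/min/kg with 15 mL/min/kg to 58 mL/min/kg as its expected range.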

Compound 3, clearance: 83 mL/min/kg
Compound 3: the middle estimate sits 2.8-fold (0.44 log units) below what was measured; measured number above the stated range.
By their numbers in this assay, from the lowest: compounds 2 and 1 (each within the scatter of the next); then compound 3.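

In this assay, ethyl in place of the amide hydrogen gives a 3.3-fold higher number from compound 2 to compound 3 (0.52 log units; beyond the scatter), so this nitrogen responds to a small added group, which the earlier pair could not show. Diethylcarbamoyl in place of isopropyl on an amine nitrogen in a ring gives a 2.2-fold higher number from compound 1 to compound 3 (0.34 log units; beyond the scatter), whereas ethylcarbamoyl stayed within the scatter of isopropyl, so a carbamoyl group alone does not set the number. No data here explain this rise. From the compounds shown here alone, how methyl or a longer chain such as propyl on this nitrogen would compare remains open.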